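Swapping the urea side group on a weak compound

The compounds below may be only part of what the source reports. "The series", "measured", "known", "first", "only" and "open" are said of these compounds alone.

In a functional assay on HCT-116 cells (Homo sapiens) (on this read-out higher numbers stand for weaker inhibition and lower numbers for stronger inhibition), compound 1 `COc1cc(NC(C)CCCNC(=O)NOCc2ccccc2)c2ncccc2c1` gives 14000 nM as a measured number. Compound 2 `COc1cc(NC(C)CCCNC(=O)N(CCO)CCO)c2ncccc2c1` gives > 100000 nM which is a limit of the assay and not a number. Compound 3 `COc1cc(NC(C)CCCNC(=O)NO)c2ncccc2c1` carries hydroxyamino in place of bis(2-hydroxyethyl)amino on a carbonyl carbon at the same place. Going by the values given here, the only measured step there is an at least 7.1-fold higher number from compound 1 to compound 2 (0.85 log units; beyond the scatter) and it ends at a limit, so its true size is unknown. Compound 3 resembles compound 1 at this place, so a lower number is expected. The estimated change is an at least 3.3-fold lower number from compound 2 to compound 3 (0.52 log units; beyond the scatter) and it could be modest. Compound 3 is estimated at 30000 nM with an expected range of 8000 nM to 100000 nM on the same read-out.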

Compound 3, half-maximal inhibitory concentration: 57000 nM
Compound 3: middle estimate off by 1.9-fold (0.28 log units), on the low side, within the range that was stated.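

In this assay, hydrogen in place of benzyl on the oxygen gives a 4.1-fold higher number from compound 1 to compound 3 (0.61 log units; beyond the scatter), so at this urea side group the benzyl goes with stronger inhibition, and the bare hydroxyamino does not match it. The other new step, an at least 1.7-fold lower number from compound 2 to compound 3 (0.24 log units; that floor lies within the scatter), has a floor that lies within the scatter, so it does not firmly separate these two side groups. Compound 2 stands at a limit of the assay and not a number: the limit of > 100000 nM in this assay, at which 1 of the 3 values shown sits.

From the compounds shown here alone, it remains open whether the ring of the benzyl matters or any carbon group on that oxygen would serve. A methyl or a longer chain such as phenylethyl there would test this.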